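Lengthening the Linker Toward the Imidazole

The source may hold more compounds than are shown below. What is called first, only, known or untested is meant among the compounds shown, and "the series" means these compounds.

In an assay on microsomes from brain (strain Sprague-Dawley) for inhibition of heme oxygenase 2 (Rattus norvegicus), read by spectrophotometry, with a stated time of 60 min (a lower number here means a stronger inhibitor, a higher number a weaker inhibitor), compound 2 `c1ccc2sc(SCCCn3ccnc3)nc2c1` gives 12500 nM, the highest of the two numbers seen so far. Going by the values given here, the only other number, compound 1 `Ic1ccc(OCCCCCn2ccnc2)cc1`, stands at 900 nM, a gap beyond the usual scatter. Compound 3 `c1ccc2sc(SCCCCn3ccnc3)nc2c1` is compound 2 with one change: (1H-imidazol-1-yl)methyl in place of 1H-imidazol-1-yl on a saturated chain carbon, three bonds along the chain from a sulfur. Among the compounds with values here, no step between measured compounds matches this change, so any expectation is uncertain. A modest downward step is expected, a 2.1-fold lower number from compound 2 to compound 3 (0.32 log units; beyond the scatter), close to the edge of the scatter. Compound 3 is therefore expected to give 6000 nM, within a range of 2000 nM to 20000 nM.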

Compound 3, half-maximal inhibitory concentration: 800 nM
Compound 3: middle estimate off by 7.5-fold (0.88 log units), on the high side; measured number below the stated range.
By their numbers in this assay, from the lowest: compounds 3 and 1 (each within the scatter of the next); then compound 2.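

On this saturated chain carbon, three bonds along the chain from a sulfur, (1H-imidazol-1-yl)methyl in place of 1H-imidazol-1-yl gives a 16-fold lower number from compound 2 to compound 3 (1.19 log units; beyond the scatter) in this assay. The imidazole ring itself stays the same, so the length of the chain alone can move the number well beyond the scatter. Nothing available here explains why the number falls.

A longer chain at this place could lower the number further or raise it again. As far as these compounds go, it also remains open whether an amine could stand in place of the imidazole.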